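The source may hold more compounds than are shown below. What is called first, only, known or untested is meant among the compounds shown, and "the series" means these compounds.

Measured in an assay on CHO cells with Alpha-2B adrenergic receptor (Homo sapiens) as the target; a higher number here means a larger maximal response, a lower number a smaller maximal response:
- compound 1, `C=C(C)c1ccccc1OC(C)C1=NCCN1`, gives 0.4
- compound 2, `CC(Oc1ccccc1Br)C1=NCCN1`, gives 0.4
- compound 3, `C=COc1ccccc1OC(C)C1=NCCN1`, gives 0.45

Compound 3 carries the largest of the three numbers, but both others sit within the usual scatter of it: the change from compound 1 to compound 3 is a number 0.050 higher from compound 1 to compound 3 (within the scatter) and that from compound 2 to compound 3 is a number 0.050 higher from compound 2 to compound 3 (within the scatter). The third pair behaves alike, with no change at the digits printed from compound 1 to compound 2 (within the scatter). Every exchange made so far at this aromatic carbon has therefore left the maximal response where it was.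

Compound 4, `CCc1ccccc1OC(C)C1=NCCN1`, continues this series: ethyl in place of vinyloxy on an aromatic carbon. The two steps that bear on it are those ending in compound 3, a number 0.050 higher from compound 1 to compound 3 (within the scatter) and a number 0.050 higher from compound 2 to compound 3 (within the scatter), both too small to count. Nothing in these three compounds suggests that an ethyl group at the same place would behave otherwise, so no step beyond the scatter is expected in this assay, in either direction. Compound 4 is therefore estimated at 0.4, with a range of 0.3 to 0.5. That estimate means a step of a number 0.050 lower from compound 3 to compound 4 (within the scatter), which is expected to lie within the scatter.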

Compound 4, intrinsic activity: the largest response reached, as a fraction of the reference agonist's: 0.5
Estimate against measurement, compound 4: 0.10 below; the measured number falls inside the stated range.
By their numbers in this assay, from the lowest: compounds 1, 2, 3 and 4 (each within the scatter of the next).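

In this assay, going by these compounds alone, ethyl in place of vinyloxy gives a number 0.050 higher from compound 3 to compound 4 (within the scatter) while ethyl in place of bromo gives a number 0.10 higher from compound 2 to compound 4 (within the scatter) and ethyl in place of 1-methylethenyl gives a number 0.10 higher from compound 1 to compound 4 (within the scatter) so this aromatic carbon now also carries a saturated carbon group, with no double bond and no hydrogen-bond acceptor, and no step leaves the scatter. The four compounds cannot be told apart by their maximal response, whether the group at this place is a halogen, an ether or a plain hydrocarbon. Nothing measured here offers an explanation for this flatness.

What the compounds leave open is whether an amine, a carboxylic acid or a longer chain at this place would move the maximal response beyond the scatter. Going by these compounds, it also remains open whether the same exchanges would matter on another aromatic carbon of the shared core.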